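Methoxy addition carried over to the fluoro analogue

This account rests on a few compounds, and the source may have more. Where it says the series, first, only, none or still open, it means among the compounds named here.

Compound 1 `COc1ccc(-c2cc(C(=O)Nc3nc4ccc(Cl)cc4s3)nc3cc(-c4ccccc4)nn23)cc1OC` in a functional assay on DU-145 cells (Homo sapiens) for cytotoxicity, read by MTT assay, with a stated time of 48 h (on this read-out higher numbers stand for weaker inhibition and lower numbers for stronger inhibition), gives 9330 nM. Compound 2 `COc1cc(-c2cc(C(=O)Nc3nc4ccc(Cl)cc4s3)nc3cc(-c4ccccc4)nn23)cc(OC)c1OC` carries one change relative to compound 1, namely (methoxy in place of hydrogen on an aromatic carbon), and in this assay compound 2 gives 38900 nM. That change made a 4.2-fold higher number from compound 1 to compound 2 (0.62 log units; beyond the scatter).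

Compound 3 `COc1ccc(-c2cc(C(=O)Nc3nc4ccc(F)cc4s3)nc3cc(-c4ccccc4)nn23)cc1OC` differs from compound 1 in the core by fluoro in place of chloro on an aromatic carbon. In this assay compound 3 gives 18600 nM, and the step is a 2.0-fold higher number from compound 1 to compound 3 (0.30 log units; within the scatter), so compound 1 and compound 3 cannot be told apart on this read-out, whereas compound 2 stands beyond the scatter from both.

Compound 4 `COc1cc(-c2cc(C(=O)Nc3nc4ccc(F)cc4s3)nc3cc(-c4ccccc4)nn23)cc(OC)c1OC` has not been measured. It differs from compound 3 by methoxy in place of hydrogen on an aromatic carbon. The surroundings of the place are described in the same words as for the change from compound 1 to compound 2, so this is the same change, made on the core of compound 3 instead of the core of compound 1. Going by the values given here, only one measured instance of it exists, so there is no second pair to check how well it transfers.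

For compound 4 in this assay a step of a 4.0-fold higher number from compound 3 to compound 4 (0.61 log units; beyond the scatter) is expected, resting on the observation that the same change gave a 4.2-fold higher number from compound 1 to compound 2 (0.62 log units; beyond the scatter). Compound 4 is therefore estimated at 75000 nM, with an expected range from 32000 nM to 160000 nM. Because compound 3 already gives 18600 nM, the number for compound 4 is expected to be among the highest in this set.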

Compound 4, half-maximal inhibitory concentration: 25700 nM
Estimate against measurement, compound 4: 2.9-fold (0.47 log units) above; the measured number lies below the stated range.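

In this assay, going from 3,4-dimethoxyphenyl to 3,4,5-trimethoxyphenyl on the fluoro core gives a 1.4-fold higher number from compound 3 to compound 4 (0.14 log units; within the scatter), so the step seen on the chloro core did not carry over in size, and the two steps differ: the same change on two cores in this assay, a 4.2-fold higher number (0.62 log units; beyond the scatter) from compound 1 to compound 2 and a 1.4-fold higher number (0.14 log units; within the scatter) from compound 3 to compound 4, 3.0-fold (0.48 log units) apart, beyond the scatter of two such steps

Read along the other edge of the same four compounds, fluoro in place of chloro gives a 1.5-fold lower number from compound 2 to compound 4 (0.18 log units; within the scatter), and this step also fails to match its earlier counterpart: the same change on two cores in this assay, a 2.0-fold higher number (0.30 log units; within the scatter) from compound 1 to compound 3 and a 1.5-fold lower number (0.18 log units; within the scatter) from compound 2 to compound 4, 3.0-fold (0.48 log units) apart, beyond the scatter of two such steps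

The two comparisons rest on the same four compounds and are one non-additive result seen from two sides, not two independent findings, so they show that a step measured on one core cannot be assumed on the other here, but they do not show what lies behind the gap or how the methoxy change would behave on any further core.

Open, as far as these compounds go, is whether a hydroxy group or an amine in the place of the added methoxy would follow the step seen on the chloro core or the one seen on the fluoro core. Equally open, from the compounds shown here alone, is whether a bromo or methyl group in place of the halogen on the core would give the same gap between the two steps.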